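Cyclopropyl for Methyl on the Core: Cytotoxicity Outlook

The compounds below may be only part of what the source reports. "The series", "measured", "known", "first", "only" and "open" are said of these compounds alone.

Compound 1 `Cc1ccc2[nH]c(=O)c(CN(Cc3ccc(C(C)(C)C)cc3)[C@@H](C)c3ccc(F)cc3)cc2c1` in a toxicity assay on MDCK cells (Canis lupus familiaris) for cytotoxicity, read by crystal violet staining, with a stated time of 48 h (on this read-out lower numbers stand for higher toxicity in this test and higher numbers for lower toxicity in this test), sits at the limit > 5000 nM.
Compound 2 `Cc1ccc2[nH]c(=O)c(CN(Cc3ccc(C(C)(C)C)cc3)C(C)c3ccc(N(C)C)c(Cl)c3)cc2c1` in this assay gives 9800 nM.

Compound 2 holds the only number shown; the other value is a limit. The step that the limit leaves unreadable from compound 1 to compound 2 is unreadable because of the limit of > 5000 nM in this assay, at which 1 of the 2 values shown sits. Compound 3 `CC(c1ccc(N(C)C)c(Cl)c1)N(Cc1ccc(C(C)(C)C)cc1)Cc1cc2cc(C3CC3)ccc2[nH]c1=O` differs from compound 2 by cyclopropyl in place of methyl on an aromatic carbon. No measured step touches this position, and the single step shown gives no size, so the step expected is a 1.1-fold lower number from compound 2 to compound 3 (0.04 log units; within the scatter). Compound 3 is therefore estimated at 9000 nM, within 3500 nM to 25000 nM.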

Compound 3, half-maximal cytotoxic concentration: > 10000 nM
Compound 3: only a limit was reported (the forecaster's own chance of this, stated with the estimate: 35%); middle value at least 1.1-fold (0.04 log units) from the limit.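

Cyclopropyl in place of methyl on an aromatic carbon gives an at least 1.0-fold higher number from compound 2 to compound 3 (0.00 log units; that floor lies within the scatter) in this assay and so provides the first readable step at this position. Compound 3 gives > 10000 nM as a limit and not a number, so only a floor for the step is known. The read-out shows no sign of higher toxicity with cyclopropyl on this carbon. Going by these compounds, how far the true value of compound 3 lies past its limit stays open. Also open, on these data alone, is how an amine, a carboxylic acid or a longer chain on this carbon would read in this assay when set against methyl and cyclopropyl.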